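This account rests on a few compounds, and the source may have more. Where it says the series, first, only, none or still open, it means among the compounds named here.

Measured compounds in a functional assay on A-375 cells (Homo sapiens) for inhibition, read by MTT assay, with a stated time of 120 h; a higher number here means a weaker inhibitor, a lower number a stronger inhibitor:
compound 1, `C/C(=C\C(=O)N1CC(C)OC(C)C1)c1ccc(NC(=O)Nc2ccc(Cl)c(C(F)(F)F)c2)cc1`, 46200 nM
compound 2, `CNC(=O)/C=C(\C)c1ccc(NC(=O)Nc2ccc(Cl)c(C(F)(F)F)c2)cc1`, > 50000 nM

In this assay compound 1 gives 46200 nM. For compound 2 only a limit is reported, > 50000 nM, which is the limit of > 50000 nM in this assay, at which 1 of the 2 values shown sits. The one measured step, an at least 1.0-fold higher number from compound 1 to compound 2 (0.03 log units; that floor lies within the scatter), lies within the scatter, so compound 2 stands at the weak end of the numbers shown without a number of its own.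

Compound 3, `C/C(=C\C(=O)NC(C)c1ccccc1)c1ccc(NC(=O)Nc2ccc(Cl)c(C(F)(F)F)c2)cc1`, differs from compound 2 by 1-phenylethyl in place of methyl on an amide-type nitrogen. No measured step covers a change on this side of the amide; the only step shown concerns the other amide substituent and stayed within the scatter. The estimate for compound 3 therefore stays close to the limit of compound 2, and compound 3 is expected to give 40000 nM, in the range 8000 nM to 100000 nM. The expected step is an at least 1.2-fold lower number from compound 2 to compound 3 (0.09 log units; that floor lies within the scatter).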

Compound 3, half-maximal inhibitory concentration: > 50000 nM
Compound 3: a limit, no number; the forecaster's own chance of this, stated with the estimate: 40%; middle value at least 1.2-fold (0.09 log units) from the limit.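

In this assay compound 3 gives only a limit, > 50000 nM, so placing 1-phenylethyl, with its six-membered aromatic ring of carbon, on the amide-type nitrogen yields no measured number, just as methyl did. The comparison with the 2,6-dimethylmorpholin-4-yl amide shows an at least 1.0-fold higher number from compound 1 to compound 3 (0.03 log units; that floor lies within the scatter), so this ring-bearing amide is not separated from compound 1, while the step between the two limits cannot be read. The limit now holds for most of the compounds shown: the limit of > 50000 nM in this assay, at which 2 of the 3 values shown sit.

The compounds shown leave open whether a primary amide, a 2-aminoethyl chain or a carboxylic acid on this nitrogen would give a number clearly short of that limit. They also leave open whether a piperazine on the carbonyl carbon would separate from compound 1.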